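Shortening the Chain on the Core of Compound 3

A few compounds are considered here, and "the series" means these few. Any claim that something is new, unique, unknown or untested is made for them only; others in the source may bear on it.

Compound 1, `CCCn1c(Cc2cc(OC)c(OC)c(OC)c2)nc2c(N)nc(F)nc21`: 25100 nM
Compound 2, `COc1cc(Cc2nc3c(N)nc(F)nc3n2CCOC(C)C)cc(OC)c1OC`: 15800 nM
Compound 3, `C=CCCCn1c(Cc2cc(OC)c(OC)c(OC)c2)nc2c(N)nc(F)nc21`: 44700 nM

All three share one core and differ only in the chain attached to an aromatic nitrogen. In a functional assay on MCF7 cells (Homo sapiens) for antiproliferative activity (on this read-out higher numbers stand for weaker inhibition and lower numbers for stronger inhibition), compound 3 has the highest number of the three: it reaches compound 1 through a 1.8-fold higher number from compound 1 to compound 3 (0.25 log units; within the scatter) and compound 2 through a 2.8-fold higher number from compound 2 to compound 3 (0.45 log units; beyond the scatter). Compound 4, `C=CCCn1c(Cc2cc(OC)c(OC)c(OC)c2)nc2c(N)nc(F)nc21`, cuts the chain of compound 3 one carbon shorter: vinyl in place of allyl on a saturated chain carbon, two bonds along the chain from an aromatic nitrogen. The step from propyl to pent-4-en-1-yl, a 1.8-fold higher number from compound 1 to compound 3 (0.25 log units; within the scatter), is the closest guide and was within the scatter, and but-3-en-1-yl sits between those two chains. Compound 4 is therefore expected to show no step beyond the scatter, a 1.3-fold lower number from compound 3 to compound 4 (0.11 log units; within the scatter), with an estimated 35000 nM and a range from 15000 nM to 80000 nM.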

Compound 4, half-maximal inhibitory concentration: 33100 nM
Estimate against measurement, compound 4: 1.1-fold (0.02 log units) above; measured number inside the range.
By their numbers in this assay, from the lowest: compounds 2, 1, 4 and 3 (each within the scatter of the next, the first and the last beyond it).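

In this assay the swap of allyl for vinyl stays within the scatter (a 1.4-fold lower number from compound 3 to compound 4 (0.13 log units; within the scatter)), and the but-3-en-1-yl chain also stays within the scatter of propyl (a 1.3-fold higher number from compound 1 to compound 4 (0.12 log units; within the scatter)). These three all-carbon chains are therefore not told apart at this position. Only the isopropoxy chain differs beyond the scatter, with weaker inhibition on going to vinyl (a 2.1-fold higher number from compound 2 to compound 4 (0.32 log units; beyond the scatter)), and no supporting data explain this. Open, from the compounds shown here alone, is whether an amine or a carboxylic acid on this chain would move the number further, and whether a much longer chain would.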